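This account rests on a few compounds, and the source may have more. Where it says the series, first, only, none or still open, it means among the compounds named here.

Working notes on the series in a functional assay on Vero cells (Chlorocebus sabaeus) for cytotoxicity; a higher number here means a weaker inhibitor, a lower number a stronger inhibitor.

Of the compounds shown here, two have numbers so far. Compound 1 `C[C@@H](C(=O)NCCS(=O)(=O)c1ccc(Br)cc1)S(=O)(=O)c1ccccc1` gives 48400 nM in this assay. Compound 2 `c1ccc(-c2nc(NCCCn3ccnc3)cc(-c3cccnc3)n2)cc1` gives 40700 nM in this assay. The two numbers lie within the scatter of each other, so compound 2 and compound 1 cannot be told apart on what is known; both read as weak inhibitors of the Vero cells.

Compound 3 `Brc1cncc(-c2cc(NCCCn3ccnc3)nc(-c3ccccc3)n2)c1` is the next to be measured. It differs from compound 2 in one place: bromo in place of hydrogen on an aromatic carbon. Within the data shown here, no measured pair shows a step of this kind, so nothing in the data fixes its size.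

On that basis the change is expected to leave the number near that of compound 2, and the step from compound 2 to compound 3 is estimated at a 1.2-fold lower number from compound 2 to compound 3 (0.09 log units; within the scatter), not clearly beyond the scatter. Compound 3 is therefore expected to give about 33000 nM in this assay, within a range of 14000 nM to 80000 nM.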

Compound 3, half-maximal inhibitory concentration: 32200 nM
The estimate for compound 3 lay 1.0-fold (0.01 log units) above the measured number; the measured number falls inside the stated range.
By their numbers in this assay, from the lowest: compounds 3, 2 and 1 (each within the scatter of the next).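

In this assay, among these compounds, going from pyridin-3-yl to 5-bromopyridin-3-yl gives a 1.3-fold lower number from compound 2 to compound 3 (0.10 log units; within the scatter), the first step that isolates a change in one place. This aromatic carbon, two atoms from the ring nitrogen, therefore carries a bromo in place of hydrogen with no shift that can be told from the scatter, although this rests on a single pair. No supporting measurement bears on this result.

The compounds shown leave open whether an amine, a carboxylic acid or a methoxy group on this same carbon would move the number beyond the scatter. Also open, from the compounds shown here alone, is whether a bromo placed elsewhere on the shared core would give a step of similar size.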